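Swapping the Methoxy for a Pyrazole on the Amide Nitrogen

This account rests on a few compounds, and the source may have more. Where it says the series, first, only, none or still open, it means among the compounds named here.

Compound 1, `CCN(Cc1cccs1)C(=O)c1cc2cc(C)ccc2[nH]1`, gives 2010 nM in an assay on HEK293 cells for agonist activity at transient receptor potential cation channel subfamily M member 8 (Homo sapiens), read by fluorescence and calcium flux, with a stated time of 15 min; a lower number here means that less compound is needed, a higher number that more compound is needed for the effect.
Compound 2, `CCCc1ccc(OCC(=O)N(CC)Cc2cccs2)cc1`, gives 1810 nM in this assay.
Compound 3, `CON(Cc1cccs1)C(=O)COc1ccc(C)cc1`, gives 10 nM in this assay.

Among these three, compound 3 stands lowest, and its gaps to compound 2 and to compound 1 both lie well beyond the usual scatter of this assay, so it needs clearly less compound than either of the others. Compounds 1 and 2 carry an ethyl on the amide-type nitrogen where compound 3 carries a methoxy, but they also differ from compound 3 elsewhere, so no single change can be credited for that gap.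

Compound 4, `Cc1ccc(OCC(=O)N(Cc2cccs2)c2c(C)n[nH]c2C)cc1`, keeps the rest of compound 3 and changes only one place: 3,5-dimethyl-1H-pyrazol-4-yl in place of methoxy on an amide-type nitrogen. Going by the values given here, no measured pair shows this change in isolation, so its effect cannot be read from the numbers at hand. Every departure from the amide-nitrogen substituent of compound 3 seen so far, in compounds 1 and 2, comes with a far higher number. A step upward, beyond the scatter, is the more likely expectation, though with wide uncertainty.

The estimate for compound 4 in this assay is therefore 300 nM, within 30 nM to 3000 nM, which is an expected step of a 30-fold higher number from compound 3 to compound 4 (1.48 log units; beyond the scatter).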

Compound 4, half-maximal effective concentration: 0.3 nM
Compound 4: middle estimate off by 1000-fold (3.00 log units), on the high side; the whole stated range lies above it.
By their numbers in this assay, from the lowest: compound 4; then compound 3; then compounds 2 and 1 (each within the scatter of the next).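

In this assay, 3,5-dimethyl-1H-pyrazol-4-yl in place of methoxy on the amide-type nitrogen gives a 33-fold lower number from compound 3 to compound 4 (1.52 log units; beyond the scatter) and is a large step, so this position accepts a much bigger group, one that brings a five-membered aromatic ring and a hydrogen-bond donor, and less compound is needed, not more. Going by these compounds alone, the earlier compounds differ from compound 3 in more than one place, so this pair is the first clean reading of this position, and it shows that replacing methoxy here need not raise the number. Nothing available explains the drop, so it cannot be said whether the ring itself, its two methyl groups or its hydrogen-bond donor accounts for it.

From the compounds shown here alone, whether an unsubstituted pyrazole, a phenyl ring or a plain methyl on the same nitrogen would also give so low a number remains open, and those comparisons would separate the contribution of the ring from that of its methyl groups. Going by these compounds, it also remains open whether the same swap would give a step of similar size on a different core, such as that of compound 1.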